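This account rests on a few compounds, and the source may have more. Where it says the series, first, only, none or still open, it means among the compounds named here.

Measured so far in a functional assay on A549 cells (Homo sapiens) for antiproliferative activity, read by MTT assay, with a stated time of 48 h (on this read-out lower numbers stand for stronger inhibition and higher numbers for weaker inhibition), are these compounds:

- compound 1 `Fc1ccc(-c2nn(-c3ccccc3)cc2-c2nc3cc(F)ccc3[nH]2)cc1` gives 1130 nM
- compound 2 `Fc1ccc(-c2nn(-c3ccccc3)cc2-c2nc3cc(Cl)ccc3[nH]2)cc1` gives 1320 nM
- compound 3 `Fc1ccc(-c2nn(-c3ccccc3)cc2-c2nc3cc(Br)ccc3[nH]2)cc1` gives 5830 nM

Compound 1 sits at the low end of this small set. The swap to chloro (a 1.2-fold higher number from compound 1 to compound 2 (0.07 log units; within the scatter)) stays within the scatter, while the swap to bromo (a 5.2-fold higher number from compound 1 to compound 3 (0.71 log units; beyond the scatter)) is modest but real, as is the move from chloro to bromo (a 4.4-fold higher number from compound 2 to compound 3 (0.65 log units; beyond the scatter)).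

Compound 4 `Fc1ccc2[nH]c(-c3cn(-c4ccccc4)nc3-c3ccc(Cl)cc3)nc2c1` keeps the fluoro of the shared core and turns 4-fluorophenyl into 4-chlorophenyl chloro in place of fluoro on an aromatic carbon with chloro in place of fluoro on an aromatic carbon. No swap at this place has been measured, so the closest guide is the same swap elsewhere in compound 1 (a 1.2-fold higher number from compound 1 to compound 2 (0.07 log units; within the scatter)) and it is only indirect.

No clear shift is therefore expected in this assay and the estimated change is a 1.3-fold higher number from compound 1 to compound 4 (0.12 log units; within the scatter) in the upward direction. Compound 4 is expected near 1500 nM with 600 nM to 4000 nM as its estimated range.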

Compound 4, half-maximal inhibitory concentration: 4610 nM
Compound 4: the middle estimate sits 3.1-fold (0.49 log units) below what was measured; measured number outside the range, above it.
By their numbers in this assay, from the lowest: compounds 1 and 2 (each within the scatter of the next); then compounds 4 and 3 (each within the scatter of the next).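

In this assay, chloro in place of fluoro on the 4-fluorophenyl group costs activity beyond the scatter: a 4.1-fold higher number from compound 1 to compound 4 (0.61 log units; beyond the scatter). The same swap at the other fluoro of compound 1 stays within the scatter (a 1.2-fold higher number from compound 1 to compound 2 (0.07 log units; within the scatter)), so the outcome of this swap depends on where it is made. Nothing available explains this difference.

Compound 4 is the only change shown at this position, and it is one halogen for another. On these data alone, how an amine, a methoxy group or a carboxylic acid would fare here remains open.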